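A few compounds are considered here, and "the series" means these few. Any claim that something is new, unique, unknown or untested is made for them only; others in the source may bear on it.

Measured so far in a functional assay on the whole organism for inhibition, with Cavia porcellus as the target; on this read-out higher numbers stand for an effect only at larger amounts of compound and lower numbers for an effect already at smaller amounts:
- compound 1 `CN(C)/C(=N\C#N)C1=CC(C)(C)Oc2ccc(S(=O)(=O)c3ccccc3)cc21`: 3630 nM
- compound 2 `CN(C)/C(=N\C#N)C1=CC(C)(C)Oc2ccc(C(F)(F)F)cc21`: 178 nM

Of these two, compound 2 holds the lower number, so it needs less compound for its effect in this assay. The next compound to be measured is compound 3 `CN(C)/C(=N\C#N)C1=CC(C)(C)Oc2ccc(Br)cc21`, which has bromo in place of trifluoromethyl on an aromatic carbon.

Among the measured compounds shown here, only one measured step bears on this change: a 20-fold lower number from compound 1 to compound 2 (1.31 log units; beyond the scatter). That large step came with trifluoromethyl in place of phenylsulfonyl on the same aromatic carbon, so the number can move a long way when this group changes. For the measured compounds named here, no bromo compound has been measured, however, and that step cannot be transferred directly. The change to compound 3 is expected to be much smaller, probably modest and toward a higher number, though it may not exceed the scatter. The expected change is a 1.7-fold higher number from compound 2 to compound 3 (0.23 log units; within the scatter). For compound 3 the estimated value is 300 nM, with an expected range from 100 nM to 900 nM.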

Compound 3, half-maximal effective concentration: > 31600 nM
Compound 3: a limit, no number; the forecaster's own chance of this, stated with the estimate: 3%; at least 100-fold (2.02 log units) between middle value and limit.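

In this assay compound 3 gives no number, only a limit of the assay: the limit of > 31600 nM in this assay, at which 1 of the 3 values shown sits.

On this aromatic carbon, bromo in place of trifluoromethyl gives an at least 170-fold higher number from compound 2 to compound 3 (2.24 log units; beyond the scatter), and bromo in place of phenylsulfonyl gives an at least 8.7-fold higher number from compound 1 to compound 3 (0.93 log units; beyond the scatter). Among the compounds shown here, the earlier pair showed only that the number moves a long way between two groups at this position, whereas these steps show that the change of a single substituent here can take the compound from a measurable effect to a limit, and they put the three groups in one order, with trifluoromethyl at the lowest number, phenylsulfonyl in the middle and bromo at the top.

The compounds shown leave open how far compound 3 lies beyond its limit, so the true size of both steps stays unknown. They also leave open how a nitrile, a chloro group or an amine on this aromatic carbon would compare with trifluoromethyl, and whether any such group would give a lower number than compound 2.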